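The source may report more compounds than this note shows. Statements on the series, on what has been measured and on what is new or still open speak of the compounds shown alone.

In a functional assay on NCI-H460 cells (Homo sapiens) for inhibition, read by MTT assay, with a stated time of 24 h, tested at 1 ug/mL (a higher number here means more inhibition of growth at the concentration tested, a lower number less inhibition of growth), compound 2 (`O=C(CCCCC(S)CCS)Nc1ccc(Cl)cc1`) gives 6.76%. Compound 1 (`O=C(CCCCC1CCSS1)Nc1ccc(OC(F)(F)F)cc1`) gives 12.2%, and these two values lie within the usual scatter of each other, so neither compound stands apart. Still unmeasured is compound 3 (`O=C(CCCCC(S)CCS)Nc1ccc(OC(F)(F)F)cc1`), which has trifluoromethoxy in place of chloro on an aromatic carbon of compound 2: trifluoromethoxy in place of chloro on an aromatic carbon. For the measured compounds named here, no measured pair shows this change on its own, so no clear shift is expected in this assay. The estimated a number 2.2 percentage points higher from compound 2 to compound 3 (within the scatter) is small and stays within the scatter. For compound 3 the expected value is 9%, with an estimated range of 1% to 20%.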

Compound 3, percent growth inhibition at one concentration: 19.1%
The estimate for compound 3 lay 10.1 percentage points below the measured number; the measured number falls inside the stated range.
By their numbers in this assay, from the lowest: compounds 2, 1 and 3 (each within the scatter of the next, the first and the last beyond it).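

In this assay, trifluoromethoxy in place of chloro on an aromatic carbon, para to a large group, gives a number 12.3 percentage points higher from compound 2 to compound 3 (beyond the scatter), so this position does respond to a change of group. Replacing the five-membered ring with an open chain gives a number 6.9 percentage points higher from compound 1 to compound 3 (within the scatter), so this assay does not separate these two forms. No measurement here explains the gain seen with trifluoromethoxy.

From the compounds shown here alone, whether an amine or a carboxylic acid on the same aromatic carbon would shift growth inhibition further remains open. So does the effect of a longer chain between the carbonyl and the sulfur-bearing end.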